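The source may report more compounds than this note shows. Statements on the series, on what has been measured and on what is new or still open speak of the compounds shown alone.

In an in vitro ADME assay on microsomes from Gut (Homo sapiens) for metabolic stability, in the presence of a further agent that is not named here (on this read-out higher numbers stand for fast clearance and lower numbers for slow clearance), compound 2 (`CC(C)(O)CCNC(=O)c1cc2cc(C#N)ccc2n1Cc1cccc(OC(F)(F)F)c1`) gives 9 mL.min-1.g-1, the lower of the two numbers, and compound 1 (`COc1ccc(Br)cc1Cn1c(C(=O)NCC(C)(C)CO)cc2cc(C#N)ccc21`) gives 94 mL.min-1.g-1. The gap between compound 2 and compound 1 lies beyond the scatter. Compound 3 (`N#Cc1ccc2c(c1)cc(C(=O)NCCC(O)(C(F)(F)F)C(F)(F)F)n2Cc1cccc(OC(F)(F)F)c1`) differs from compound 2 by 2,2,2-trifluoro-1-hydroxy-1-(trifluoromethyl)ethyl in place of 1-hydroxy-1-methylethyl on a saturated chain carbon, two bonds along the chain from an amide-type nitrogen, with 2,2,2-trifluoro-1-hydroxy-1-(trifluoromethyl)ethyl in place of 1-hydroxy-1-methylethyl on a saturated chain carbon, two bonds along the chain from an amide-type nitrogen. Among the compounds with values here, no measured pair shows this exchange, so the expectation is uncertain. A small rise in this assay, not beyond the scatter, is expected, and the estimated step is a 1.7-fold higher number from compound 2 to compound 3 (0.22 log units; within the scatter). The estimated intrinsic clearance of compound 3 is 15 mL.min-1.g-1, with an expected range of 5 mL.min-1.g-1 to 45 mL.min-1.g-1.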

Compound 3, intrinsic clearance in microsomes: < 6 mL.min-1.g-1
Compound 3: no number, only a limit; the forecaster's own chance of this, stated with the estimate: 10%; middle value at least 2.5-fold (0.39 log units) away from the limit.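

The exchange of 1-hydroxy-1-methylethyl for 2,2,2-trifluoro-1-hydroxy-1-(trifluoromethyl)ethyl at this chain carbon gives an at least 1.5-fold lower number from compound 2 to compound 3 (0.17 log units; that floor lies within the scatter), so in this assay it brings no rise in clearance, though the floor alone does not establish a real fall. Compound 3 reads < 6 mL.min-1.g-1, which is a limit of the assay and not a number. The true size of the step stays unknown because the read-out ends there: the limit of < 6 mL.min-1.g-1 in this assay, at which 1 of the 3 values shown sits.

Going by these compounds, whether an amine in place of the hydroxyl, or a single trifluoromethyl in place of one methyl, would keep clearance this low stays open.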